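Aryl variation on the piperazine amine: compound 2 to compound 3

The compounds below may be only part of what the source reports. "The series", "measured", "known", "first", "only" and "open" are said of these compounds alone.

Compound 1 `CCCc1nc(-c2ccccc2)c(CNCCN2CCN(c3ccc(Cl)cc3)CC2)o1` gives 55.8% in an assay on HEK293 cells for inhibition of Voltage-dependent T-type calcium channel subunit alpha-1G (Homo sapiens), read by fluorescence, tested at 10 uM; a lower number here means less inhibition, a higher number more inhibition at the concentration tested (going by the name of the read-out). Within the data shown here, compound 2 `CCCc1nc(-c2ccccc2)c(CNCCN2CCN(c3cccc(C)c3)CC2)o1` gives 43.1%, the lowest of the two numbers so far; the step of a number 12.7 percentage points lower from compound 1 to compound 2 (beyond the scatter) lies beyond the scatter. Compound 3 `CCCc1nc(-c2ccccc2)c(CNCCN2CCN(c3ccccc3OC)CC2)o1` differs from compound 2 by 2-methoxyphenyl in place of 3-methylphenyl on an amine nitrogen in a ring. Among the measured compounds shown here, no measured step covers this exchange; the only step on record swaps a different group at the same position and was modest. A step of about a number 1.9 percentage points higher from compound 2 to compound 3 (within the scatter) is expected, not beyond the scatter. Compound 3 is estimated at 45%, in the range 25% to 65%.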

Compound 3, a percentage reported as inhibition, at one concentration (the size of the read-out at that concentration, not a potency): 39.7%
The estimate for compound 3 lay 5.3 percentage points above the measured number; low and high end bracket the measured number.
By their numbers in this assay, from the lowest: compounds 3 and 2 (each within the scatter of the next); then compound 1.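

In this assay, 2-methoxyphenyl on the amine nitrogen in the ring stays within the scatter of 3-methylphenyl (a number 3.4 percentage points lower from compound 2 to compound 3 (within the scatter)). The step from 4-chlorophenyl is beyond the scatter and modest (a number 16.1 percentage points lower from compound 1 to compound 3 (beyond the scatter)), so compound 1 alone stands apart, higher than both compound 2 and compound 3. No supporting data bear on why these aryl groups read as they do.

Each aryl group here differs in both substituent and ring position, so the two effects remain unseparated. From the compounds shown here alone, how an unsubstituted phenyl or a pyridine ring would read at this nitrogen remains open.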